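Swapping a sulfanyl for a benzylamino on the shared core

The source may report more compounds than this note shows. Statements on the series, on what has been measured and on what is new or still open speak of the compounds shown alone.

Compound 1 `Nc1cc(N)c2nc(-c3ccccc3)c(Sc3ccc(F)cc3)nc2c1` is measured in a functional assay on Hs-578T cells (Homo sapiens) for inhibition, read by sulforhodamine B assay, with a stated time of 48 h (on this read-out higher numbers stand for weaker inhibition of growth and lower numbers for stronger inhibition of growth), where compound 1 gives 61700 nM. Compound 2 `COc1cc(CNc2nc3cc(N)cc(N)c3nc2-c2ccccc2)cc(OC)c1OC` gives 33100 nM in this assay. Compound 3 `CCOC(=O)[C@H](CCC(=O)O)NC(=O)c1ccc(Oc2nc3cc(N)cc(N)c3nc2-c2ccccc2)cc1` reports in this assay only a limit and no number, < 100000 nM; this is the limit of < 100000 nM in this assay, at which 1 of the 3 values shown sits. Of the two numbers, compound 1 sits at the higher one, yet its gap to compound 2 lies within the scatter, so no order between the two is claimed. Compound 4 `Nc1cc(N)c2nc(-c3ccccc3)c(NCc3ccc(F)cc3)nc2c1` is not yet measured. It differs from compound 1 in one place: (4-fluorobenzyl)amino in place of (4-fluorophenyl)sulfanyl on an aromatic carbon. For the measured compounds named here, no measured pair shares this change, so a step no larger than the scatter, in either direction, is expected, a 1.4-fold lower number from compound 1 to compound 4 (0.14 log units; within the scatter). Compound 4 is estimated at 45000 nM in this assay, within 15000 nM to 100000 nM.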

Compound 4, concentration for total growth inhibition: < 100000 nM
Compound 4 gave a limit, no number; the forecaster's own chance of this, stated with the estimate: 20%; the middle value does not contradict the limit.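

Compound 4 gives only a limit and no number, so no step from compound 1 can be read: the limit of < 100000 nM in this assay, at which 2 of the 4 values shown sit.

As far as these compounds go, whether (4-fluorobenzyl)amino in place of (4-fluorophenyl)sulfanyl on the shared core changes growth inhibition at all remains open.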